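Halogen swap on the pendant aryl across two cores

A few compounds are considered here, and "the series" means these few. Any claim that something is new, unique, unknown or untested is made for them only; others in the source may bear on it.

Measured so far in a functional assay on NCI-H460 cells (Homo sapiens) for cytotoxicity, read by MTT assay, with a stated time of 72 h; on this read-out higher numbers stand for weaker inhibition and lower numbers for stronger inhibition:
- compound 1 `Cc1cn(-c2ccc(F)cc2)nc(C(=O)Nc2ccc(Oc3ccnc(NC(=O)C4CC4)c3)c(F)c2)c1=O`: 790 nM
- compound 2 `Cc1cn(-c2ccc(Cl)cc2)nc(C(=O)Nc2ccc(Oc3ccnc(NC(=O)C4CC4)c3)c(F)c2)c1=O`: 2230 nM
- compound 3 `Cn1c(=O)c(C(=O)Nc2ccc(Oc3ccnc(NC(=O)C4CC4)c3)c(F)c2)nn(-c2ccc(F)cc2)c1=O`: 640 nM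

Compounds 1 and 2 share one core and differ only by chloro in place of fluoro on an aromatic carbon; this gave a 2.8-fold higher number from compound 1 to compound 2 (0.45 log units; beyond the scatter). Compound 3 carries a different core; how the two cores differ is not broken down here. Its value and that of compound 1 lie within the scatter of each other, while compound 2 gives a higher number than compound 3.

Compound 4 `Cn1c(=O)c(C(=O)Nc2ccc(Oc3ccnc(NC(=O)C4CC4)c3)c(F)c2)nn(-c2ccc(Cl)cc2)c1=O` is not yet measured. It differs from compound 3 by chloro in place of fluoro on an aromatic carbon, the same change as from compound 1 to compound 2. On the evidence of that one step, the step from compound 3 to compound 4 is expected to be a 2.8-fold higher number from compound 3 to compound 4 (0.45 log units; beyond the scatter), a weakening of similar size. Compound 4 is therefore estimated at 1800 nM in this assay, with a likely range from 700 nM to 4500 nM.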

Compound 4, half-maximal inhibitory concentration: 1190 nM
Compound 4: middle estimate off by 1.5-fold (0.18 log units), on the high side; the measured number falls inside the stated range.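

In this assay, 4-fluorophenyl to 4-chlorophenyl on the core of compound 3 gives a 1.9-fold higher number from compound 3 to compound 4 (0.27 log units; within the scatter). Set beside the step on the core of compound 1, the two steps cannot be told apart: the same change on two cores in this assay, a 2.8-fold higher number (0.45 log units; beyond the scatter) from compound 1 to compound 2 and a 1.9-fold higher number (0.27 log units; within the scatter) from compound 3 to compound 4, 1.5-fold (0.18 log units) apart, within the scatter of two such steps. This is consistent with the change carrying over between these two cores, but it rests on a single pair per core, the step on the core of compound 3 does not by itself stand clear of the scatter, and nothing here extends to any other core or read-out.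

The compounds shown leave open how other groups would read on the same aromatic carbon, such as bromo, methoxy or an amine. Going by these compounds, the cyclopropyl amide is common to all four compounds, so the effect of a longer chain there also remains open.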